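Mirror Image of a Bis-Dioxolane Pyrimidopyrimidine Inhibitor

The source may report more compounds than this note shows. Statements on the series, on what has been measured and on what is new or still open speak of the compounds shown alone.

Compound 1 `CC1(C)OC[C@H](COc2nc(N3CCCCC3)c3nc(OC[C@H]4COC(C)(C)O4)nc(N4CCCCC4)c3n2)O1`: 87%
Compound 2 `COC[C@H](COc1nc(N2CCCCC2)c2nc(OC[C@H](COC)OC)nc(N3CCCCC3)c2n1)OC`: 100%

In a functional assay on L1210 cells (Mus musculus) for inhibition, read by thymidine incorporation, tested at 10 uM (a lower number here means a weaker effect, a higher number a stronger effect of the compound at the concentration tested), compound 1 gives 87%, the lower of the two numbers, while compound 2 gives 100%, a difference beyond the usual scatter. Compound 3 `CC1(C)OC[C@@H](COc2nc(N3CCCCC3)c3nc(OC[C@@H]4COC(C)(C)O4)nc(N4CCCCC4)c3n2)O1` has not yet been measured. It differs from compound 1 as follows: the two compounds have the same atoms and bonds and differ only in configuration as drawn: 2 of 2 stereo elements differ (all stereocentres are inverted: mirror images); a stereocentre at a saturated ring carbon is drawn S in compound 1 and R in compound 3; a stereocentre at a saturated ring carbon is drawn S in compound 1 and R in compound 3. Among the measured compounds shown here, no step between two measured compounds of this kind is available, so the size of the change cannot be anchored. Compound 3 is expected to give 85% (range 65% to 100%), an estimated step of a number 2 percentage points lower from compound 1 to compound 3 (within the scatter), within the scatter.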

Compound 3, a percentage reported as inhibition, at one concentration (the size of the read-out at that concentration, not a potency): 100%
Compound 3: middle estimate off by 15 percentage points, on the low side; the range from low to high includes it.
By their numbers in this assay, from the lowest: compound 1; then compounds 2 and 3 (each within the scatter of the next).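

In this assay, inverting both stereocentres gives a number 13 percentage points higher from compound 1 to compound 3 (beyond the scatter). Among the compounds shown here, this is the first step in which only one kind of change is at work, and it shows that configuration alone can shift this read-out beyond the scatter. The step can be assigned to configuration because nothing else changes: the fact that compounds 1 and 3 differ only in the configuration as drawn

Going by these compounds, since both stereocentres change together, the share of each one stays open. So does the effect of a hydroxyl group or an amine on these side chains in this assay.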